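Mirror-Image Change and Expected Lipophilicity

The source may hold more compounds than are shown below. What is called first, only, known or untested is meant among the compounds shown, and "the series" means these compounds.

In a physicochemical assay for lipophilicity (on this read-out lower numbers stand for lower lipophilicity and higher numbers for higher lipophilicity), the measured compounds give:
compound 1, `COc1cc(-c2nnc3n2CCCC3c2ccc(Cl)c(Cl)c2)ccc1-c1cnc(C)o1`: 3.2
compound 2, `COc1cc(-c2nnc3n2CCCC3(Oc2ccc(F)c(Cl)c2)C(C)(C)O)ccc1-c1cnc(C)o1`: 3.2
compound 3, `COc1cc(-c2nnc3n2CCC[C@@]3(Oc2cc(F)c(F)c(F)c2)C(C)(C)O)ccc1-c1cnc(C)o1`: 3.2

On these numbers compound 3 stands level with compound 1 and with compound 2 at the digits shown; neither gap reaches beyond the usual scatter of this kind of measurement, so no ordering among the three can be read from them.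

The unmeasured compound 4 is `COc1cc(-c2nnc3n2CCC[C@]3(Oc2cc(F)c(F)c(F)c2)C(C)(C)O)ccc1-c1cnc(C)o1`. Set against compound 3, the difference is this: the two compounds have the same atoms and bonds and differ only in configuration as drawn: 1 of 1 stereo elements differ; a stereocentre at a saturated ring carbon is drawn S in compound 3 and R in compound 4. Going by the values given here, no step between two measured compounds that differ in one place is available here, so there is no measured precedent for a change of this kind within this set.

The expectation is that the step of no change at the digits printed from compound 3 to compound 4 (within the scatter) shows no change beyond the scatter in this assay, with the same atoms and bonds kept and only the drawn configuration at one saturated ring carbon switched. Accordingly compound 4 is estimated at 3.2, within a range from 2.9 to 3.5.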

Compound 4, distribution coefficient: 3.2
The estimate for compound 4 equals the measured number at the digits printed; low and high end bracket the measured number.
By their numbers in this assay, from the lowest: compounds 1, 2, 3 and 4 (each within the scatter of the next).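

Switching the drawn configuration at the saturated ring carbon gives no change at the digits printed from compound 3 to compound 4 (within the scatter) in this assay. Going by these compounds alone, this is the first pair in the set that differs in one place only, so it gives a direct reading that the earlier compounds, which differ in more than one place, could not give. The step can be tied to this single stereocentre, because nothing else separates the two structures: the fact that compounds 3 and 4 differ only in the configuration as drawn.

On these data alone, it remains open whether the same switch would also stay within the scatter in a compound carrying an amine or a carboxylic acid. The compounds shown also leave open whether the two configurations would behave alike in any other kind of test.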